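From furan to thiophene on a shared core

The source may hold more compounds than are shown below. What is called first, only, known or untested is meant among the compounds shown, and "the series" means these compounds.

For the measured compounds named here, in an ADME assay on J774.A1 cells (Mus musculus) for cytotoxicity, read by MTT assay, with a stated time of 72 h (a lower number here means that less compound is tolerated, a higher number that more compound is tolerated), compound 2 (`Clc1ccc(COC(CCn2ccnc2)c2ccco2)c(Cl)c1`) gives 56200 nM as the only number so far. Compound 1 (`Clc1ccc(COC(CCn2cncn2)c2cccs2)c(Cl)c1`) has the entry "not determined" (no result reported) and so offers no comparison. Compound 3 (`Clc1ccc(COC(CCn2ccnc2)c2cccs2)c(Cl)c1`) carries thiophen-2-yl in place of furan-2-yl on a saturated chain carbon bound to an oxygen on a saturated carbon and a saturated chain carbon. Going by the values given here, no measured step is available as a guide, so in this assay a change no larger than the usual scatter is expected, leaning slightly towards a lower number. The estimated move (a 1.3-fold lower number from compound 2 to compound 3 (0.13 log units; within the scatter)) stays within that scatter. Compound 3 is expected at 42000 nM (range 15000 nM to 100000 nM).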

Compound 3, half-maximal cytotoxic concentration: 29700 nM
Beside the measured number, compound 3's estimate is 1.4-fold (0.15 log units) above it; measured number inside the range.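

In this assay, putting thiophen-2-yl in place of furan-2-yl on this saturated chain carbon gives a 1.9-fold lower number from compound 2 to compound 3 (0.28 log units; within the scatter) and so stays within the usual scatter of repeated measurements. At this position, then, exchanging one five-membered aromatic ring for the other does not clearly separate the two compounds. No evidence is available that bears on this result.

Going by these compounds, whether an amine or a carboxylic acid on this carbon would shift the number beyond that scatter remains open. For the compounds shown here, compound 1 has no result, so no step to it can be read.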